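From 1-hydroxypropyl to propanoyl on a short-lived compound

This account rests on a few compounds, and the source may have more. Where it says the series, first, only, none or still open, it means among the compounds named here.

In an ADME assay on microsomes from liver (Homo sapiens) for metabolic stability, read by LC-MS, using NADPH, with a stated time of 120 min, tested at 1 uM (on this read-out higher numbers stand for a longer-lived compound and lower numbers for a shorter-lived compound), compound 1 (`CCC(O)CNC(=O)C[C@H](CCC1CCCCC1)NC(=O)c1cc(-c2c(OC)cccc2OC)n(CC(C)C)n1`) gives 0.0535 h, and compound 2 (`CC[C@@H](O)CNC(=O)C[C@H](CCC1CCCCC1)NC(=O)c1cc(-c2c(OC)cccc2OC)n(CC(C)C)n1`) gives 0.0517 h. Among the measured compounds shown here, these two values lie within the scatter of each other, so compound 2 stands level with the only other measured compound.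

The next structure is compound 3 (`CCC(=O)CNC(=O)C[C@H](CCC1CCCCC1)NC(=O)c1cc(-c2c(OC)cccc2OC)n(CC(C)C)n1`), in which propanoyl takes the place of 1-hydroxypropyl on a saturated chain carbon bound to an amide-type nitrogen: propanoyl in place of 1-hydroxypropyl on a saturated chain carbon bound to an amide-type nitrogen.

For the measured compounds named here, only one measured step bears on this change, a 1.0-fold lower number from compound 1 to compound 2 (0.01 log units; within the scatter). What separates those two compounds is the fact that one of compounds 1 and 2 is drawn with a defined configuration and the other without, at the place where they differ. That step touches the same group, but it leaves the atoms and bonds untouched, so it shows only that drawing the configuration in compound 2 left this assay within the scatter. Going by the values given here, no measured step replaces 1-hydroxypropyl with propanoyl, so the estimate stays close to the value of compound 2, 0.0517 h, with a wide margin.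

The expected change is a 1.1-fold higher number from compound 2 to compound 3 (0.03 log units; within the scatter), which means no shift beyond the scatter in either direction.

For compound 3 the estimated half-life is 0.055 h, with an expected range of 0.027 h to 0.11 h.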

Compound 3, half-life: 0.0592 h
For compound 3 the middle estimate is 1.1-fold (0.03 log units) below the measured one, within the range that was stated.
By their numbers in this assay, from the lowest: compounds 2, 1 and 3 (each within the scatter of the next).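

In this assay, propanoyl in place of 1-hydroxypropyl on a saturated chain carbon bound to an amide-type nitrogen gives a 1.1-fold higher number from compound 2 to compound 3 (0.06 log units; within the scatter), and the same change gives a 1.1-fold higher number from compound 1 to compound 3 (0.04 log units; within the scatter). The earlier pair differed only in how one stereocentre was drawn, whereas here the atoms and bonds themselves change: the hydrogen-bond donor and the defined stereocentre of 1-hydroxypropyl give way to the double bond of propanoyl, and the half-life still shows no shift beyond the scatter. The compounds shown offer no reason for this level result.

Going by these compounds, all three compounds carry a four-heavy-atom group at this place on the same core, so it remains open whether a group of a different kind there, such as an amine, a carboxylic acid or a longer chain, would move the half-life beyond the scatter. On these data alone, it also remains open how the S form of 1-hydroxypropyl, drawn on its own, would compare, and whether a change elsewhere on the shared core would matter more than any change at this place.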